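This account rests on a few compounds, and the source may have more. Where it says the series, first, only, none or still open, it means among the compounds named here.

Of the compounds shown here, three built on the same core have been measured in a functional assay on CHO cells for antagonist activity at Orexin receptor type 2 (Homo sapiens), read by FLIPR and calcium flux; on this read-out lower numbers stand for stronger inhibition and higher numbers for weaker inhibition. Compound 1 `Cc1ccc(C)c(NC(=O)CSc2nnc(-c3ccoc3C)n2Cc2ccco2)c1` gives 398 nM. Compound 3 `Cc1occc1-c1nnc(SCC(=O)Nc2cccc(Cl)c2)n1Cc1ccco1` gives 63.1 nM, the lowest of the two numbers shown. For compound 2 `Cc1cccc(C)c1NC(=O)CSc1nnc(-c2ccoc2C)n1Cc1ccco1` the assay reports only a limit, > 15800 nM, and not a number. All three differ only in the ring attached to the amide-type nitrogen, and each step between them is large: a 6.3-fold lower number from compound 1 to compound 3 (0.80 log units; beyond the scatter), an at least 250-fold lower number from compound 2 to compound 3 (2.39 log units; beyond the scatter), and an at least 39-fold higher number from compound 1 to compound 2 (1.59 log units; beyond the scatter). Compound 4 `COc1ccc(NC(=O)CSc2nnc(-c3ccoc3C)n2Cc2ccco2)cc1` alters this same ring once more: 4-methoxyphenyl in place of 3-chlorophenyl on an amide-type nitrogen. Among the measured compounds shown here, none of the measured steps tests a 4-methoxyphenyl, so the direction of this change is not fixed by what is known; what the three measured steps do show is that changes on this ring readily move the number well beyond the scatter, and that the 3-chlorophenyl of compound 3 sits at the low end. A higher number, meaning weaker inhibition, is therefore expected for compound 4, with a step of a 6.3-fold higher number from compound 3 to compound 4 (0.80 log units; beyond the scatter). Compound 4 is estimated at 400 nM, between 100 nM and 3000 nM.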

Compound 4, inhibition constant: 200 nM
Beside the measured number, compound 4's estimate is 2.0-fold (0.30 log units) above it, within the range that was stated.
By their numbers in this assay, from the lowest: compound 3; then compounds 4 and 1 (each within the scatter of the next). At a limit, above all of these: compound 2.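

In this assay, replacing the 3-chlorophenyl with a 4-methoxyphenyl, which brings one hydrogen-bond acceptor, gives a 3.2-fold higher number from compound 3 to compound 4 (0.50 log units; beyond the scatter), so compound 3 keeps the lowest number of the series. The 4-methoxyphenyl and the 2,5-dimethylphenyl cannot be told apart on this read-out, with a 2.0-fold lower number from compound 1 to compound 4 (0.30 log units; within the scatter). The step against the 2,6-dimethylphenyl is large, an at least 79-fold lower number from compound 2 to compound 4 (1.89 log units; beyond the scatter), but compound 2 gives only a limit of the assay and not a number: the limit of > 15800 nM in this assay, at which 1 of the 4 values shown sits.

A 4-chlorophenyl and a 3-methoxyphenyl on the same nitrogen would help separate the effect of each group from the effect of its place on the ring. As far as these compounds go, how a plain phenyl, or a phenyl carrying an amine or a carboxylic acid, would read in this assay remains open.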